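The compounds below may be only part of what the source reports. "The series", "measured", "known", "first", "only" and "open" are said of these compounds alone.

Values so far in a functional assay on SK-OV-3 cells (Homo sapiens) for inhibition, read by MTT assay; a higher number here means a weaker inhibitor, a lower number a stronger inhibitor:
- compound 1 `COc1ccc(/C=C2\c3cc(OC)c(OC)c(OC)c3CC[C@@H]2O)cc1C(N)=O`: 1440 nM
- compound 2 `COc1ccc(/C=C2\c3cc(OC)c(OC)c(OC)c3CC[C@H]2O)cc1F`: 720 nM
- compound 3 `COc1ccc(/C=C2\c3cc(OC)c(OC)c(OC)c3CC[C@H]2O)cc1O`: 1590 nM

Compound 3 sits level with compound 1, within the scatter, and higher than compound 2 by a margin beyond the scatter. The next entry, compound 4 `COc1ccc(/C=C2\c3cc(OC)c(OC)c(OC)c3CC[C@H]2O)cc1C(N)=O`, differs from compound 3 as follows: carbamoyl in place of hydroxy on an aromatic carbon. This is carbamoyl in place of hydroxy on an aromatic carbon, ortho to a methoxy group and meta to a large group.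

For the measured compounds named here, one measured step touches this place: a 2.2-fold higher number from compound 2 to compound 3 (0.34 log units; beyond the scatter). It is modest and involves fluoro and hydroxy, not carbamoyl, so it offers only a rough guide to how far a swap here can move the number. Compound 1 also carries carbamoyl, but with the other configuration at the hydroxy-bearing carbon, and the weight of that configuration has not been measured on its own. With compound 3 at 1590 nM and compound 1 at 1440 nM, no step beyond the scatter is expected in this assay. The expected change is a 1.1-fold lower number from compound 3 to compound 4 (0.06 log units; within the scatter). The estimate for compound 4 is 1400 nM, with an expected range of 600 nM to 3000 nM.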

Compound 4, half-maximal inhibitory concentration: 1920 nM
Estimate against measurement, compound 4: 1.4-fold (0.14 log units) below; low and high end bracket the measured number.
By their numbers in this assay, from the lowest: compounds 2, 1, 3 and 4 (each within the scatter of the next, the first and the last beyond it).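

In this assay, carbamoyl and hydroxy on this aromatic carbon cannot be told apart, with a 1.2-fold higher number from compound 3 to compound 4 (0.08 log units; within the scatter), even though carbamoyl brings more heavy atoms than hydroxy. Carbamoyl in place of fluoro gives a 2.7-fold higher number from compound 2 to compound 4 (0.43 log units; beyond the scatter), a step beyond the scatter that points the same way as the step from fluoro to hydroxy, so among these three groups in this configuration, only fluoro stands apart, with the lowest number. The configuration at the saturated ring carbon can now be read for the first time, and with a 1.3-fold higher number from compound 1 to compound 4 (0.12 log units; within the scatter), its weight lies within the scatter for the carbamoyl pair, a reading that is clean on this ground: the fact that compounds 1 and 4 differ only in the configuration as drawn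

On these data alone, whether the same holds for the fluoro or hydroxy compounds stays open, as the configuration can be read here only with carbamoyl on the aromatic carbon. Also open, as far as these compounds go, is whether the lower number of compound 2 is particular to fluoro or extends to chloro, and how an amine or a carboxylic acid at this place would compare in this assay.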